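Pyrazole carboxamides: cytotoxicity notes toward compound 4

This account rests on a few compounds, and the source may have more. Where it says the series, first, only, none or still open, it means among the compounds named here.

Compound 1 `CC(C)Cc1nn(-c2nccs2)cc1C(=O)NCc1ccc(F)cc1F` gives 83600 nM in a toxicity assay on HepG2 2.2.15 cells (Homo sapiens) for cytotoxicity, read by CCK-8 assay, with a stated time of 8 days; a higher number here means that more compound is tolerated, a lower number that less compound is tolerated.
Compound 2 `CCOC(=O)c1cn(-c2ccc(C(=O)O)cc2)nc1CC(C)C` reaches only the assay limit, > 100000 nM in this assay.
Compound 3 `CC(C)Cc1nn(-c2cccc(F)c2)cc1C(=O)NCc1ccncc1` likewise sits at the assay limit, > 100000 nM in this assay.

Among the measured compounds shown here, compound 1 carries the only numeric reading in this assay; the other two readings are limits, as the limit of > 100000 nM in this assay, at which 2 of the 3 values shown sit, records. Compound 4 `CC(C)Cc1nn(-c2nccs2)cc1C(=O)NCc1ccc(N)cc1` differs from compound 1 by 4-aminophenyl in place of 2,4-difluorophenyl on a saturated chain carbon bound to an amide-type nitrogen. For the measured compounds named here, no measured step between these compounds exists, so the expected size rests on the spread of values seen. The step of a 1.1-fold higher number from compound 1 to compound 4 (0.06 log units; within the scatter) is expected to be small and, if anything, toward more compound tolerated, staying close to the limit where two of three compounds sit. Compound 4 is estimated at 95000 nM, with a range of 40000 nM to 200000 nM.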

Compound 4, half-maximal cytotoxic concentration: > 100000 nM
Compound 4: a limit, no number; the forecaster's own chance of this, stated with the estimate: 50%; middle value at least 1.0-fold (0.02 log units) from the limit.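

Replacing 2,4-difluorophenyl with 4-aminophenyl on a saturated chain carbon bound to an amide-type nitrogen gives an at least 1.1-fold higher number from compound 1 to compound 4 (0.07 log units; that floor lies within the scatter), the first step read at this position. The step is only a floor, and its true size cannot be read. Compound 1 remains the only compound with a numeric reading, while the others share one limit: the limit of > 100000 nM in this assay, at which 3 of the 4 values shown sit.

Still open, as far as these compounds go, is whether any group at this position moves the reading clearly beyond the scatter. An unsubstituted phenyl or a 4-hydroxyphenyl on the same carbon would separate the loss of fluorine from the gain of the amine.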